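Swapping the Azide for a Carbamate on a Quinoxaline Dioxide

This account rests on a few compounds, and the source may have more. Where it says the series, first, only, none or still open, it means among the compounds named here.

Compound 2 `COc1ccc2c(c1)[n+]([O-])c(C(=O)N=[N+]=[N-])c(C)[n+]2[O-]` is the reference point here. Going by the values given here, in a functional assay on Ehrlich cells (Mus musculus) for cytotoxicity, read by trypan blue exclusion, with a stated time of 2 h, tested at 50 ug/mL (on this read-out lower numbers stand for a stronger effect and higher numbers for a weaker effect at the one concentration tested), compound 2 gives 6.2%, the low end of the three numbers known. Compound 3 `COc1ccc(NC(=O)Nc2c(C)[n+]([O-])c3ccc(Cl)cc3[n+]2[O-])cc1` gives 10.3%, which lies within the scatter of compound 2, while compound 1 `Cc1c(C(=O)N=[N+]=[N-])[n+]([O-])c2cc(Cl)ccc2[n+]1[O-]` gives 70.3%, far away from it. Among the compounds with values here, the one single-point step known runs a number 64.1 percentage points lower from compound 1 to compound 2 (beyond the scatter), and it concerns a different spot on the shared core than the change examined now.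

Compound 4 `COc1ccc2c(c1)[n+]([O-])c(NC(=O)OC(C)C)c(C)[n+]2[O-]` differs from compound 2 by a group of 7 heavy atoms (4 carbon, 1 nitrogen, 2 oxygen; no ring) in place of a group of 5 heavy atoms (1 carbon, 3 nitrogen, 1 oxygen; no ring), on an aromatic carbon. Within the data shown here, no measured step touches this exact exchange. What the data do offer is compound 3, which carries a nitrogen-linked carbonyl group at the same position on a chloro-bearing core and still gives a low number, whereas compound 1 with the azide carbonyl gives a high one. On that basis a low number is expected for compound 4 as well, with a step of a number 5.8 percentage points higher from compound 2 to compound 4 (within the scatter) that stays within the scatter. Compound 4 is estimated at 12%, ranging from 3% to 45%.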

Compound 4, a percentage reported as activity, at one concentration (the size of the read-out at that concentration, not a potency): 76.2%
Beside the measured number, compound 4's estimate is 64.2 percentage points below it; the measured number lies above the stated range.
By their numbers in this assay, from the lowest: compounds 2 and 3 (each within the scatter of the next); then compounds 1 and 4 (each within the scatter of the next).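

At this position on the shared core, exchanging the azide carbonyl group for (isopropoxycarbonyl)amino has a large effect: in this assay the step is a number 70 percentage points higher from compound 2 to compound 4 (beyond the scatter), which means a much weaker effect at the one concentration tested. The earlier single-place step, a number 64.1 percentage points lower from compound 1 to compound 2 (beyond the scatter), came from methoxy in place of chloro, so the low number of compound 2 now proves sensitive to a change at a second place on the core. Nothing measured here accounts for the size of this new step.

Going by these compounds, it remains open whether the nitrogen link, the carbonyl or the isopropyl end of the entering group drives the change, which a plain amine or a methyl carbamate at this position could help separate. On these data alone, whether the same exchange would matter on the chloro-bearing core of compound 1 also remains open.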